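From methoxycarbonyl to carbamoyl on the shared core

The compounds below may be only part of what the source reports. "The series", "measured", "known", "first", "only" and "open" are said of these compounds alone.

Measured in a functional assay for inhibition, with Homo sapiens as the target; on this read-out lower numbers stand for stronger inhibition and higher numbers for weaker inhibition:
Compound 1 `COc1cc(OC)c(C(=O)/C=C/c2ccc(Cl)cc2)c(OC)c1`: 970 nM
Compound 2 `COC(=O)c1ccc(/C=C/C(=O)c2c(OC)cc(OC)cc2OC)cc1`: 1930 nM

Compound 2, at 1930 nM, stands within the scatter of compound 1, at 970 nM. Within the data shown here, only one measured step exists in this short series: a 2.0-fold higher number from compound 1 to compound 2 (0.30 log units; within the scatter), with methoxycarbonyl in place of chloro on an aromatic carbon. Compound 3 `COc1cc(OC)c(C(=O)/C=C/c2ccc(C(N)=O)cc2)c(OC)c1`, not yet measured, differs from compound 2 in one place: amino in place of methoxy on a carbonyl carbon. This is amino in place of methoxy on a carbonyl carbon, which turns methoxycarbonyl into carbamoyl. Among the measured compounds shown here, no measured step covers this exact exchange, so the evidence is indirect. For the measured compounds named here, the one available step stayed within the scatter, and it gives no direction for the change. In this assay, no step beyond the scatter is therefore expected, and the estimated change is a 1.1-fold higher number from compound 2 to compound 3 (0.06 log units; within the scatter). For compound 3 the estimated value is 2200 nM, with an expected range from 800 nM to 6000 nM.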

Compound 3, half-maximal inhibitory concentration: 1790 nM
Compound 3: middle estimate off by 1.2-fold (0.09 log units), on the high side; the range from low to high includes it.
By their numbers in this assay, from the lowest: compounds 1, 3 and 2 (each within the scatter of the next).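

In this assay, among these compounds, amino in place of methoxy on the carbonyl carbon gives a 1.1-fold lower number from compound 2 to compound 3 (0.03 log units; within the scatter) and so stays within the scatter, which is the first measured reading of a change at this carbonyl carbon. Carbamoyl in place of chloro on the aromatic carbon gives a 1.8-fold higher number from compound 1 to compound 3 (0.27 log units; within the scatter) and also stays within the scatter, so chloro, methoxycarbonyl and carbamoyl at this place on the shared core all lie within the scatter of one another, and the hydrogen-bond donor that enters with amino moves the number beyond the scatter in neither step. Nothing available accounts for this result.

Going by these compounds, it remains open whether a carboxylic acid, an amine or a longer chain such as ethoxycarbonyl at this place would also stay within the scatter. On these data alone, the three compounds show no group here that produces a step beyond the scatter, so how far this place tolerates change is still unknown.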